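Methylating the Phenol of a Triazole-Linked Dimethoxyphenyl Analogue

This account rests on a few compounds, and the source may have more. Where it says the series, first, only, none or still open, it means among the compounds named here.

Among the measured compounds shown here, compound 1 `COc1cc(OC)cc(-n2cc(-c3ccc(O)c(OC)c3)nn2)c1` is the only member of this small set with a single number in a functional assay on MDA-MB-231 cells (Homo sapiens) for cytotoxicity, read by MTT assay (on this read-out higher numbers stand for weaker inhibition and lower numbers for stronger inhibition), where compound 1 gives 10000 nM. Compound 2 `COc1cc(-c2cn(-c3cc(OC)c(OC)c(OC)c3)nn2)ccc1O` carries an additional methoxy and in this assay reaches only a limit of the assay, > 10000 nM. Compound 3 `COc1cc(-c2cn(-c3ccc(OC)c(OC)c3)nn2)ccc1O` has no result in this assay, "not determined" (no result reported). For the measured compounds named here, the one measured step, a number no lower from compound 1 to compound 2 (the limit leaves the size open), rests on the limit of > 10000 nM in this assay, at which 1 of the 3 values shown sits, and so leaves its size open. Compound 4 `COc1cc(OC)cc(-n2cc(-c3ccc(OC)c(OC)c3)nn2)c1` differs from compound 1 by methyl in place of hydrogen on an oxygen on an aromatic ring. Going by the values given here, no measured step covers a hydroxy-to-methoxy change, so the expectation for compound 4 rests on compound 1 alone, whose 10000 nM is already weak. Compound 4 is therefore expected to give 10000 nM, between 3000 nM and 30000 nM, in this assay. The estimated step of no change at the digits printed from compound 1 to compound 4 (within the scatter) is thus none beyond the scatter.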

Compound 4, half-maximal inhibitory concentration: > 1000 nM
Compound 4 was reported as a limit; the forecaster's own chance of this, stated with the estimate: 50%; the middle value is on the limit's open side.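

Among the compounds shown here, compound 4 is reported only as a limit, so no step from compound 1 to compound 4 can be read in this assay. The compounds shown leave open whether hydroxy to methoxy changes the read-out at all.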